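The compounds below may be only part of what the source reports. "The series", "measured", "known", "first", "only" and "open" are said of these compounds alone.

Two measured compounds share one core and differ only in the group on the outer aromatic ring. Compound 1 `CC1CC/C(=N\Nc2ccc(Cl)cc2)c2ncc(C(=O)O)c(=O)n21` carries a chloro group there; in a functional assay on the whole organism for inhibition, with Rattus norvegicus as the target (on this read-out lower numbers stand for an effect already at smaller amounts and higher numbers for an effect only at larger amounts of compound), compound 1 gives 0.5 umol/kg. Compound 2 `COc1ccc(N/N=C2\CCC(C)n3c2ncc(C(=O)O)c3=O)cc1` carries a methoxy group in its place; in this assay compound 2 gives 0.8 umol/kg. For the measured compounds named here, on the two numbers known, compound 2 stands beside compound 1, the only measured step being a 1.6-fold higher number from compound 1 to compound 2 (0.20 log units; within the scatter), so the two cannot be told apart on this read-out.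

Compound 3 `CC1CC/C(=N\Nc2ccc([N+](=O)[O-])cc2)c2ncc(C(=O)O)c(=O)n21` has not yet been measured. Its difference from compound 2 is nitro in place of methoxy on an aromatic carbon. Going by the values given here, no measured step involves a nitro group, so the one step known, a 1.6-fold higher number from compound 1 to compound 2 (0.20 log units; within the scatter), offers only indirect guidance: exchanging one group for another at this place left the number within the scatter. On that basis, compound 3 is expected to show no step beyond the scatter in this assay, an estimated 1.1-fold lower number from compound 2 to compound 3 (0.06 log units; within the scatter). The estimate for compound 3 is 0.7 umol/kg, with a range from 0.3 umol/kg to 1.8 umol/kg.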

Compound 3, dose for 50% inhibition: 0.8 umol/kg
For compound 3 the middle estimate is 1.1-fold (0.06 log units) below the measured one, within the range that was stated.
By their numbers in this assay, from the lowest: compounds 1, 2 and 3 (each within the scatter of the next).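

Placing nitro on this aromatic carbon, para to a large group, gives no change at the digits printed from compound 2 to compound 3 (within the scatter), and the same group compared with chloro gives a 1.6-fold higher number from compound 1 to compound 3 (0.20 log units; within the scatter). Until now a single exchange was known at this position, whereas three groups can now be compared: chloro, methoxy and nitro, the last built from nitrogen and oxygen and carrying a double bond outside aromatic rings, and none of the three can be told apart in this assay. No measurement of any property of these groups is at hand that could account for this sameness.

Still open, going by these compounds, is whether this flat picture holds for other kinds of group at this place, such as an amine, a hydroxyl group or a longer chain, or whether one of them would finally produce a step beyond the scatter. Also open, on these data alone, is whether changes elsewhere on the shared core, such as an amide in place of the carboxylic acid, would move the number more than any exchange on the outer aromatic ring has so far.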